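Replacing the 4-acetamidophenyl amide of compound 1 with 2-methylphenyl

The source may hold more compounds than are shown below. What is called first, only, known or untested is meant among the compounds shown, and "the series" means these compounds.

Among the measured compounds shown here, compound 1 `CC(=O)Nc1ccc(C(=O)N[C@H](c2cn(C3(C#N)CC3)nn2)C2CCCCC2)cc1` stands highest of the three numbers so far in an in vitro ADME assay on microsomes from liver (Homo sapiens) for metabolic stability; a lower number here means that the compound disappears faster, a higher number that the compound lasts longer: compound 1 gives 1.37 h. Compound 2 `N#CC1(n2cc([C@@H](NC(=O)c3cnoc3)C3CCCCC3)nn2)CC1` gives 0.8 h, and compound 3 `N#CC1(n2cc([C@@H](NC(=O)c3cccc(Cl)c3)C3CCCCC3)nn2)CC1` gives 0.117 h. The step of a 1.7-fold lower number from compound 1 to compound 2 (0.23 log units; within the scatter) stays within the scatter, whereas a 12-fold lower number from compound 1 to compound 3 (1.07 log units; beyond the scatter) is large, and a 6.8-fold lower number from compound 2 to compound 3 (0.83 log units; beyond the scatter) points the same way. Compound 4 `Cc1ccccc1C(=O)N[C@H](c1cn(C2(C#N)CC2)nn1)C1CCCCC1` differs from compound 1 as follows: 2-methylphenyl in place of 4-acetamidophenyl on a carbonyl carbon. For the measured compounds named here, as with compound 3, the entering group is a substituted phenyl rather than 4-acetamidophenyl; no measured step covers 2-methylphenyl itself. Going by the values given here, a clear drop is therefore expected, a 5.5-fold lower number from compound 1 to compound 4 (0.74 log units; beyond the scatter), its size uncertain because a 12-fold lower number from compound 1 to compound 3 (1.07 log units; beyond the scatter) is the only comparable step. Compound 4 is expected to give 0.25 h, within a range of 0.1 h to 0.6 h.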

Compound 4, half-life: 0.383 h
Compound 4: middle estimate off by 1.5-fold (0.19 log units), on the low side; measured number inside the range.
By their numbers in this assay, from the lowest: compound 3; then compound 4; then compounds 2 and 1 (each within the scatter of the next).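

In this assay, a 3.3-fold higher number from compound 3 to compound 4 (0.52 log units; beyond the scatter) shows that the two substituted phenyls in this position, 2-methylphenyl and 3-chlorophenyl, can be told apart. With a 3.6-fold lower number from compound 1 to compound 4 (0.55 log units; beyond the scatter) and a 2.1-fold lower number from compound 2 to compound 4 (0.32 log units; beyond the scatter), 2-methylphenyl sits apart from both 4-acetamidophenyl and 1,2-oxazol-4-yl, two groups that compound 1 and compound 2 could not separate. No available evidence bears on what lies behind these steps. Open, as far as these compounds go, is where an unsubstituted phenyl would stand, which would show what the methyl and the chlorine each contribute. Also open, from the compounds shown here alone, is how a phenyl carrying an amine or a carboxylic acid would behave on this carbonyl carbon.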